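Returning a ring to the amino substituent

The compounds below may be only part of what the source reports. "The series", "measured", "known", "first", "only" and "open" are said of these compounds alone.

Compound 3 `CCCN(CCC)c1ccc2cc(NC(=O)CCc3ccc(C(F)(F)F)cc3)ccc2n1` gives 490 nM in an assay on isolated protein for displacement of a labelled ligand from melanin-concentrating hormone receptor 1 (Homo sapiens) (on this read-out lower numbers stand for stronger inhibition and higher numbers for weaker inhibition), the highest of the three numbers recorded. Compound 1 `CC1CCCN1c1ccc2cc(NC(=O)CCc3ccc(C(F)(F)F)cc3)ccc2n1` gives 5 nM and compound 2 `CN(c1ccc2cc(NC(=O)CCc3ccc(C(F)(F)F)cc3)ccc2n1)C1CCCC1` gives 2 nM. Both steps of a 98-fold higher number from compound 1 to compound 3 (1.99 log units; beyond the scatter) and a 250-fold higher number from compound 2 to compound 3 (2.39 log units; beyond the scatter) are large, so the dipropylamino compound stands far above either neighbour. Going by the values given here, compound 4 `CC(=O)NC1CCN(c2ccc3cc(NC(=O)CCc4ccc(C(F)(F)F)cc4)ccc3n2)C1` carries 3-acetamidopyrrolidin-1-yl in place of dipropylamino on an aromatic carbon; like compound 1 it bears a five-membered ring on that nitrogen, though with an acetamido group no measured compound holds. A large step in the opposite sense is therefore expected, a 33-fold lower number from compound 3 to compound 4 (1.51 log units; beyond the scatter), resting on a 98-fold higher number from compound 1 to compound 3 (1.99 log units; beyond the scatter), with some allowance for the unfamiliar acetamido. Compound 4 is estimated at 15 nM, between 3 nM and 80 nM.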

Compound 4, half-maximal inhibitory concentration: 5 nM
Compound 4: the middle estimate sits 3.0-fold (0.48 log units) above what was measured; the range from low to high includes it.
By their numbers in this assay, from the lowest: compound 2; then compounds 1 and 4 (each within the scatter of the next); then compound 3.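

At this carbon next to the ring nitrogen, a ring on the amino nitrogen brings the number back down even when it carries an acetamido group (a 98-fold lower number from compound 3 to compound 4 (1.99 log units; beyond the scatter)) in this assay. Against the 2-methylpyrrolidin-1-yl compound the change is not detectable (no change at the digits printed from compound 1 to compound 4 (within the scatter)), so this position accepts a ring substituent bearing a hydrogen-bond donor. The cyclopentyl(methyl)amino compound still keeps a modest edge (a 2.5-fold higher number from compound 2 to compound 4 (0.40 log units; beyond the scatter)). No evidence on hand accounts for these steps. As far as these compounds go, whether a primary amine or a carboxylic acid on that ring would hold this level stays open.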